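This account rests on a few compounds, and the source may have more. Where it says the series, first, only, none or still open, it means among the compounds named here.

Measured in a functional assay on HepG2 cells (Homo sapiens) for antiproliferative activity, read by CCK-8 assay, with a stated time of 48 h; a higher number here means a weaker inhibitor, a lower number a stronger inhibitor:
- Compound 1 `COc1ccc(/C=C\c2cc(OC)c(OC)c(OC)c2)cc1OCc1ccc(C=O)cc1`: 800 nM
- Compound 2 `COc1ccc(/C=C\c2cc(OC)c(OC)c(OC)c2)cc1OCc1ccc(CN2CCCC[C@@H]2C(=O)O)cc1`: > 10000 nM (a limit of the assay, not a number)
- Compound 3 `COc1ccc(/C=C\c2cc(OC)c(OC)c(OC)c2)cc1OCc1ccc(CNCCO)cc1`: 5900 nM

Of the two actual numbers, compound 3 holds the higher one, 5900 nM, while compound 1 lies lower at 800 nM.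

Compound 4 `COc1ccc(/C=C\c2cc(OC)c(OC)c(OC)c2)cc1OCc1ccc(CNCCN(C)C)cc1` differs from compound 3 in one place: dimethylamino in place of hydroxy on a saturated chain carbon, two bonds along the chain from an amine nitrogen. In words, this is dimethylamino in place of hydroxy on a saturated chain carbon, two bonds along the chain from an amine nitrogen.

Going by the values given here, no measured step makes this exact exchange, so the evidence is indirect. Putting ((2-hydroxyethyl)amino)methyl in place of formyl gave a 7.4-fold higher number from compound 1 to compound 3 (0.87 log units; beyond the scatter). Putting (2-carboxypiperidin-1-yl)methyl in place of formyl gave an at least 12-fold higher number from compound 1 to compound 2 (1.09 log units; beyond the scatter). Both of these large moves remove the formyl, which compound 3 has already lost. The closest comparison changes the group on the same saturated chain carbon and gives an at least 1.6-fold lower number from compound 2 to compound 3 (0.22 log units; that floor lies within the scatter).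

On that basis, no step beyond the scatter is expected in this assay, and the estimated change is a 1.1-fold lower number from compound 3 to compound 4 (0.03 log units; within the scatter). Compound 4 might also end at the limit of > 10000 nM in this assay, at which 1 of the 3 values shown sits. Compound 4 is expected near 5500 nM, with an estimated range from 2000 nM to 10000 nM.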

Compound 4, half-maximal inhibitory concentration: 4400 nM
Beside the measured number, compound 4's estimate is 1.3-fold (0.10 log units) above it; the measured number falls inside the stated range.
By their numbers in this assay, from the lowest: compound 1; then compounds 4 and 3 (each within the scatter of the next). At a limit, above all of these: compound 2.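

In this assay, the step from hydroxy to dimethylamino on a saturated chain carbon, two bonds along the chain from an amine nitrogen, gives a 1.3-fold lower number from compound 3 to compound 4 (0.13 log units; within the scatter), so this exchange of 1 heavy atom for 3, and of 1 hydrogen-bond donor for none, leaves no readable difference. Set against the formyl group, the new side chain gives a 5.5-fold higher number from compound 1 to compound 4 (0.74 log units; beyond the scatter), and so the gap first seen with the 2-hydroxyethyl chain stays in place with the 2-(dimethylamino)ethyl chain. The comparison with the 2-carboxypiperidin-1-yl group gives only a floor, an at least 2.2-fold lower number from compound 2 to compound 4 (0.35 log units; beyond the scatter), since that group's reading is a limit and not a number: the limit of > 10000 nM in this assay, at which 1 of the 4 values shown sits.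

Open, going by these compounds, is whether the end of this chain matters at all, as a longer chain, a carboxylic acid or a morpholine ring at the same place could still shift the value in either direction. Also open, on these data alone, is whether the gap to the formyl group belongs to the amine nitrogen itself, which a simple hydroxymethyl group on the same aromatic carbon would help to separate.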